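A few compounds are considered here, and "the series" means these few. Any claim that something is new, unique, unknown or untested is made for them only; others in the source may bear on it.

Measured compounds:
- compound 1, `COc1cc(Nc2nc(C(=N)Nc3ccc(N4CCN(C)CC4)cc3)cc3c(-c4ccccc4)n[nH]c23)cc(OC)c1OC`: 4600 nM
- compound 2, `COc1ccc(Cn2nc(-c3ccccc3)c3cc(C(=N)Nc4cccc(C(F)(F)F)c4)nc(NC4CCCCC4)c32)cc1`: see below
- compound 3, `N=C(Nc1cccc(C(F)(F)F)c1)c1cc2c(-c3ccccc3)n[nH]c2cn1`: 22300 nM

These three compounds share a core and were tested in a functional assay on MDA-MB-231 cells (Homo sapiens) for cytotoxicity, read by MTT assay, with a stated time of 72 h; on this read-out higher numbers stand for weaker inhibition and lower numbers for stronger inhibition. Compound 1 gives 4600 nM in this assay. Compound 2 gives only a limit of the assay in this assay, > 50000 nM, so no number is known for it. Compound 3 gives 22300 nM in this assay, which is the higher of the two numbers; the value of compound 1 lies lower than it by a margin beyond the usual scatter. One of the three results sits at the limit (the limit of > 50000 nM in this assay, at which 1 of the 3 values shown sits).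

The next compound, compound 4 `N=C(Nc1ccccc1)c1cc2c(-c3ccccc3)n[nH]c2cn1`, has not been measured. It differs from compound 3 in one place: hydrogen in place of trifluoromethyl on an aromatic carbon, with the change sitting meta to a large group. Among the compounds with values here, no measured pair shows this exact change, so the expected size of the step rests on no direct precedent. The expectation is that the step from compound 3 to compound 4 stays small, a 1.1-fold higher number from compound 3 to compound 4 (0.05 log units; within the scatter), with no clear direction beyond the scatter. Compound 4 is therefore estimated at 25000 nM in this assay, within a range from 8000 nM to 80000 nM.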

Compound 4, half-maximal inhibitory concentration: 11000 nM
Compound 4: the middle estimate sits 2.3-fold (0.36 log units) above what was measured, within the range that was stated.
By their numbers in this assay, from the lowest: compound 1; then compound 4; then compound 3. At a limit, above all of these: compound 2.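

Within the data shown here, the earlier compounds differed from each other in several places at once, so none of their gaps could be tied to a single group; this pair gives the first reading of one change. In this assay, putting hydrogen in place of trifluoromethyl on this aromatic carbon, meta to a large group, gives a 2.0-fold lower number from compound 3 to compound 4 (0.31 log units; beyond the scatter), a modest gain in strength that lies beyond the usual scatter, which shows that this group of four heavy atoms is not required for the cytotoxic effect of this pair and that the simpler compound 4 holds up at least as well. Nothing measured here accounts for the direction of this step, and the one assay limit among the results has no bearing on it.

On these data alone, with only hydrogen and trifluoromethyl compared at this place, it remains open how a chlorine atom, a methoxy group or an amine on the same carbon would read. As far as these compounds go, it is also open whether the same change would give a similar step on a compound with further groups on the shared core, such as compound 2, whose result is only a limit.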